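The source may report more compounds than this note shows. Statements on the series, on what has been measured and on what is new or still open speak of the compounds shown alone.

Measured compounds:
Compound 1 `C#CCN(CCCCOc1ccc2ccc(=O)oc2c1)Cc1cccc(OC)c1` gives 2340 nM in an assay on isolated protein for inhibition of Amine oxidase [flavin-containing] B (Homo sapiens), read by fluorescence and Amplex Red, with stated times of 15 min and 20 min; on this read-out lower numbers stand for stronger inhibition and higher numbers for weaker inhibition.
Compound 2 `C#CCN(CCCOc1ccc2ccc(=O)oc2c1)Cc1ccc(C)cc1` gives 7380 nM in this assay.
Compound 3 `C#CCN(CCCOc1ccc2ccc(=O)oc2c1)Cc1cccc(OC)c1` gives 4590 nM in this assay.

Compound 1 shows the lowest number of the three in this assay; compound 3 sits within the scatter of it, while compound 2 lies beyond it. Compound 4 `C#CCN(C)CCCCOc1ccc2ccc(=O)oc2c1` differs from compound 1 by hydrogen in place of 3-methoxyphenyl on a saturated chain carbon bound to an amine nitrogen. Going by the values given here, the only measured step at this position, a 1.6-fold lower number from compound 2 to compound 3 (0.21 log units; within the scatter), swaps one substituted phenyl for another and stays within the scatter. Among the compounds with values here, no measured pair shows the whole 3-methoxybenzyl replaced by methyl; compounds 1 and 3 both carry the 3-methoxybenzyl, and their values lie within the scatter of each other. The change from compound 1 to compound 4 is therefore untested in this set and removes far more than any measured step does. Without a step to anchor it, the expectation for compound 4 is a higher number in this assay, a step of a 4.3-fold higher number from compound 1 to compound 4 (0.63 log units; beyond the scatter), with a wide range. Compound 4 is estimated at 10000 nM, between 3000 nM and 40000 nM.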

Compound 4, half-maximal inhibitory concentration: 27 nM
Compound 4: middle estimate off by 370-fold (2.57 log units), on the high side, outside the stated range (below it).
By their numbers in this assay, from the lowest: compound 4; then compounds 1, 3 and 2 (each within the scatter of the next, the first and the last beyond it).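

In this assay, going by these compounds alone, replacing 3-methoxybenzyl with methyl is a large step, an 87-fold lower number from compound 1 to compound 4 (1.94 log units; beyond the scatter), and it shows that this position is far from flat, which the earlier compounds could not reveal. Within the data shown here, the only earlier step here, a 1.6-fold lower number from compound 2 to compound 3 (0.21 log units; within the scatter), exchanged one substituted phenyl for another and stayed within the scatter, so it tested the substituents on the phenyl but not whether the phenyl should be there at all. With the core and the chain of compound 1 held constant, the result places the largest effect seen in this series on the presence of the whole 3-methoxyphenyl group, and no supporting data on the compounds bear on why the step is so large.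

As far as these compounds go, it remains open whether ethyl or unsubstituted benzyl at this position would give a number close to that of compound 4 or of compound 1, and so whether the change is gradual or abrupt. From the compounds shown here alone, it is also open whether methyl in place of 3-methoxybenzyl has the same effect on the shorter chain of compound 3.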